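What one added methyl may do to half-life

A few compounds are considered here, and "the series" means these few. Any claim that something is new, unique, unknown or untested is made for them only; others in the source may bear on it.

compound 1 `Nc1ncnc2c1nc(Sc1cc3occc3cc1Br)n2CCC1CCN(C=O)CC1` gives 0.3 h
compound 2 `Nc1ncnc2c1nc(Sc1cc3c(cc1Br)OCCO3)n2CCC1CCN(C(=O)CO)CC1` gives 0.85 h
compound 3 `C[C@H](O)C(=O)N1CCC(CCn2c(Sc3cc4c(cc3Br)OCCO4)nc3c(N)ncnc32)CC1` gives 0.43 h

In an in vivo ADME assay on the whole organism (strain Swiss) for metabolic stability, with Mus musculus as the target, read by LC-MS, at a dose of 2.5 mg/kg by the intravenous route (a lower number here means that the compound disappears faster, a higher number that the compound lasts longer), compound 2 gives 0.85 h as its half-life. Compound 1 lies lower than compound 2 by more than the usual scatter, while compound 3 cannot be told apart from it.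

The next structure is compound 4 `C[C@@H](O)C(=O)N1CCC(CCn2c(Sc3cc4c(cc3Br)OCCO4)nc3c(N)ncnc32)CC1`, which differs from compound 2 in a single place. Its hydroxymethyl becomes 1-hydroxyethyl, described as methyl in place of hydrogen on a saturated chain carbon bound to a carbonyl carbon and an oxygen on a saturated carbon.

Within the data shown here, the only measured step carrying this change is a 2.0-fold lower number from compound 2 to compound 3 (0.30 log units; within the scatter), and a single step is thin evidence. The expectation in this assay is therefore a small fall, or nothing beyond the scatter. The estimated step is a 1.5-fold lower number from compound 2 to compound 4 (0.19 log units; within the scatter), which stays inside that scatter. For compound 4 the estimated half-life is 0.55 h, with an expected range from 0.3 h to 1 h as the likely span.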

Compound 4, half-life: 0.6 h
Beside the measured number, compound 4's estimate is 1.1-fold (0.04 log units) below it, within the range that was stated.
By their numbers in this assay, from the lowest: compounds 1, 3, 4 and 2 (each within the scatter of the next, the first and the last beyond it).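

With compound 4, the methyl on this carbon has now been seen in both drawn configurations, and this step too stays inside the scatter in this assay with a 1.4-fold lower number from compound 2 to compound 4 (0.15 log units; within the scatter) as its size. The two methyl compounds cannot be told apart from each other either, with a 1.4-fold higher number from compound 3 to compound 4 (0.14 log units; within the scatter) between them, and this pair isolates the drawn configuration at this one carbon: the fact that compounds 3 and 4 differ only in the configuration as drawn. For these compounds, then, neither adding the methyl nor changing its drawn configuration gives a change in half-life that can be separated from the scatter.

Still open, as far as these compounds go, is whether an amine, a carboxylic acid or a longer chain on this same carbon would give a step beyond the scatter. The compounds shown also leave open whether the methyl step would stay this small with a different group on the shared core.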